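The compounds below may be only part of what the source reports. "The series", "measured", "known", "first", "only" and "open" are said of these compounds alone.

Compound 2 `CCN1CCN(CCCSc2nnc(-c3ccc(C)cc3)[nH]2)CC1` carries an ethyl group on the amine nitrogen of its ring. In a functional assay on COLO 205 cells (Homo sapiens) for cytotoxicity, read by MTT assay, with a stated time of 24 h (a lower number here means a stronger inhibitor, a higher number a weaker inhibitor), compound 2 gives > 300000 nM, which is a limit of the assay and not a number. Compound 2 thus sits at the limit of > 300000 nM in this assay, at which 1 of the 2 values shown sits. Its neighbour compound 1 `Cc1ccc(-c2nnc(SCCCN3CCN(c4cccc(Cl)c4)CC3)[nH]2)cc1` carries a 3-chlorophenyl group on that nitrogen instead, and in this assay compound 1 gives 139000 nM; the step of an at least 2.1-fold higher number from compound 1 to compound 2 (0.33 log units; beyond the scatter) is the only measured step shown, and it concerns a different place in the molecule. Compound 3 `CCN1CCN(CCCSc2nnc(-c3ccccc3Cl)[nH]2)CC1` differs from compound 2 by 2-chlorophenyl in place of 4-methylphenyl on an aromatic carbon. No measured step touches this position, so the numbers shown give no direction for the change. Compound 3 is therefore expected to remain near the same level, with the step of a number no higher from compound 2 to compound 3 (the limit leaves the size open) expected to fall within the scatter. The estimate for compound 3 in this assay is 300000 nM, in a range from 100000 nM to 900000 nM, most likely reported once more as a limit.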

Compound 3, half-maximal inhibitory concentration: > 300000 nM
Compound 3: only a limit was reported; the forecaster's own chance of this, stated with the estimate: 70%; the middle value lies on the limit itself.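

In this assay, going by these compounds alone, compound 3 gives > 300000 nM, again a limit of the assay and not a number, so no step between compound 2 and compound 3 can be read. The compounds shown leave open whether 2-chlorophenyl in place of 4-methylphenyl on an aromatic carbon changes the value at all.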